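This account rests on a few compounds, and the source may have more. Where it says the series, first, only, none or still open, it means among the compounds named here.

Within the data shown here, compound 2 `C=CCOc1cc(OC)c(C(=O)/C=C/c2ccc(OC)cc2)c(OCC=C)c1` gives 99900 nM in an ADME assay on Vero cells (Chlorocebus sabaeus) for cytotoxicity, read by MTT assay (on this read-out higher numbers stand for weaker inhibition and lower numbers for stronger inhibition), the higher of the two numbers measured so far; compound 1 `C=CCOc1cc(OC)c(C(=O)/C=C/c2ccc(O)cc2)c(OCC=C)c1` gives 76400 nM, and the step of a 1.3-fold higher number from compound 1 to compound 2 (0.12 log units; within the scatter) lies within the scatter. Compound 3 `C=CCOc1cc(OC)c(C(=O)/C=C/c2ccccn2)c(OCC=C)c1` differs from compound 2 by pyridin-2-yl in place of 4-methoxyphenyl on a double-bonded chain carbon bound to a double-bonded chain carbon. Among the measured compounds shown here, no measured step exchanges one ring for another; the single step available, a 1.3-fold higher number from compound 1 to compound 2 (0.12 log units; within the scatter), only alters a group on the ring that leaves here. With both measured numbers sitting high and close together, compound 3 is expected to sit near them, with an expected step of a 1.2-fold lower number from compound 2 to compound 3 (0.10 log units; within the scatter). Compound 3 is estimated at 80000 nM, between 40000 nM and 160000 nM.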

Compound 3, half-maximal inhibitory concentration: 2800 nM
Estimate against measurement, compound 3: 29-fold (1.46 log units) above; measured number outside the range, below it.
By their numbers in this assay, from the lowest: compound 3; then compounds 1 and 2 (each within the scatter of the next).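

In this assay, swapping the whole ring on this double-bonded chain carbon matters far more than changing the group carried on that ring. Pyridin-2-yl in place of 4-methoxyphenyl gives (a 36-fold lower number from compound 2 to compound 3 (1.55 log units; beyond the scatter)), and pyridin-2-yl in place of 4-hydroxyphenyl gives (a 27-fold lower number from compound 1 to compound 3 (1.44 log units; beyond the scatter)), so both changes point to much stronger inhibition of the cells. Nothing given here explains this shift. Still open, from the compounds shown here alone, is whether unsubstituted phenyl or pyridin-4-yl on this carbon would give a number near compound 3 or near compound 2, which would help separate the effect of having a ring nitrogen from that of its place in the ring.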